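Cyano in Place of Methoxy on a Shared Core

The source may report more compounds than this note shows. Statements on the series, on what has been measured and on what is new or still open speak of the compounds shown alone.

Three compounds share one core and differ only in the group on the outer carbon ring. Compound 1 `Cc1ccc(-c2nc3cccnc3o2)cc1` carries a methyl group, compound 2 `Fc1ccc(-c2nc3cccnc3o2)cc1` a fluoro group, and compound 3 `COc1ccc(-c2nc3cccnc3o2)cc1` a methoxy group. In a functional assay on the whole organism for inhibition, with Rattus norvegicus as the target, at a dose of 30 mg/kg (a higher number here means more inhibition at the dose given (going by the name of the read-out), a lower number less inhibition), compound 1 gives 0%, compound 2 gives 27%, and compound 3 gives 29%. Compound 3 lies clearly apart from compound 1, as shown by a number 29 percentage points higher from compound 1 to compound 3 (beyond the scatter), yet it sits within the scatter of compound 2, as shown by a number 2 percentage points higher from compound 2 to compound 3 (within the scatter); compound 2 and compound 3 therefore belong together at the upper end, while compound 1 stands alone at the bottom.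

Compound 4 `N#Cc1ccc(-c2nc3cccnc3o2)cc1` is the next step from compound 3: cyano in place of methoxy on an aromatic carbon. For the measured compounds named here, no measured step involves a cyano group, so nothing shows directly what this change does. Going by the values given here, the steps that bear on it concern the same place on the ring: a number 27 percentage points higher from compound 1 to compound 2 (beyond the scatter) and a number 29 percentage points higher from compound 1 to compound 3 (beyond the scatter) show that leaving methyl behind for either fluoro or methoxy brought a modest rise, while a number 2 percentage points higher from compound 2 to compound 3 (within the scatter) shows that fluoro and methoxy gave the same result within the scatter. Two different replacements at this place thus landed at about one level. On that basis compound 4 is expected to stay near that level, with only a small downward step, a number 9 percentage points lower from compound 3 to compound 4 (within the scatter), expected to lie within the scatter. The estimate for compound 4 in this assay is 20%, with a range from 0% to 45%.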

Compound 4, a percentage reported as inhibition, in the whole organism at one dose (the size of the read-out at that dose, not a potency): 17%
Estimate against measurement, compound 4: 3 percentage points above; the range from low to high includes it.
By their numbers in this assay, from the lowest: compound 1; then compounds 4, 2 and 3 (each within the scatter of the next, the first and the last beyond it).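

In this assay, for the compounds shown here, cyano is, apart from methyl, the only group at this position that separates from methoxy (a number 12 percentage points lower from compound 3 to compound 4 (beyond the scatter)), yet it cannot be told apart from fluoro (a number 10 percentage points lower from compound 2 to compound 4 (within the scatter)). The single level shared by fluoro and methoxy therefore has a blurred lower edge: compound 2 lies within the scatter of both compound 3 and compound 4, even though those two lie apart from each other. Cyano also keeps a clear gain over methyl (a number 17 percentage points higher from compound 1 to compound 4 (beyond the scatter)), so all three replacements of methyl on this aromatic carbon stand apart from it, and no measurement at hand offers a reason for any of these differences.

The compounds shown leave open whether an amine, a carboxylic acid or a longer chain such as propyl at this position would stay with these three groups or fall back to the level of compound 1, at 0%. They also leave open whether these small gaps would hold at other doses, since every number here comes from a single dose in the whole animal.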